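The source may hold more compounds than are shown below. What is called first, only, known or untested is meant among the compounds shown, and "the series" means these compounds.

Values in a functional assay on HCT-116 cells (Homo sapiens) for antiproliferative activity, read by MTT assay, with a stated time of 24 h; on this read-out higher numbers stand for weaker inhibition and lower numbers for stronger inhibition:
- compound 1 `C#CCOc1ccc2c(=O)c(-c3cc(OC)c(OC)cc3OC)coc2c1`: 8050 nM
- compound 2 `COc1cc(OC)c(-c2coc3cc(OCc4ccccc4C)ccc3c2=O)cc1OC`: 2900 nM
- compound 3 `COc1cc(OC)c(-c2coc3cc(OCc4cccc(F)c4)ccc3c2=O)cc1OC`: 4920 nM

These compounds share a core and differ in one place. Compound 3, at 4920 nM, cannot be separated from either of the others: the data show a 1.6-fold lower number from compound 1 to compound 3 (0.21 log units; within the scatter) and a 1.7-fold higher number from compound 2 to compound 3 (0.23 log units; within the scatter). Only the remaining pair stands clearly apart, with a 2.8-fold lower number from compound 1 to compound 2 (0.44 log units; beyond the scatter).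

The next compound, compound 4 `COc1cc(OC)c(-c2coc3cc(OCc4cccc(Br)c4)ccc3c2=O)cc1OC`, has bromo in place of fluoro on an aromatic carbon, meta to a large group: bromo in place of fluoro on an aromatic carbon. No swap of one halogen for another has been measured here, so the evidence is indirect. The closest case is the exchange of 2-methylphenyl for 3-fluorophenyl, which gave a 1.7-fold higher number from compound 2 to compound 3 (0.23 log units; within the scatter). Even the larger exchange of ethynyl for 2-methylphenyl gave only a 2.8-fold lower number from compound 1 to compound 2 (0.44 log units; beyond the scatter). A small change, with no clear direction, therefore seems likely in this assay. The expected result is a 1.2-fold lower number from compound 3 to compound 4 (0.09 log units; within the scatter), which would not be a real difference if it stays within the scatter. The estimated value for compound 4 is 4000 nM, with an expected range from 1700 nM to 9000 nM.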

Compound 4, half-maximal inhibitory concentration: 1200 nM
For compound 4 the middle estimate is 3.3-fold (0.52 log units) above the measured one; measured number outside the range, below it.
By their numbers in this assay, from the lowest: compound 4; then compounds 2, 3 and 1 (each within the scatter of the next, the first and the last beyond it).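

In this assay, going by these compounds alone, the halogen on this aromatic carbon matters: exchanging a single atom, bromo for fluoro, gives a 4.1-fold lower number from compound 3 to compound 4 (0.61 log units; beyond the scatter), whereas among the earlier compounds only one exchange of the whole group on the chain carbon went beyond the scatter. The new member also stands clear of the other two, with a 2.4-fold lower number from compound 2 to compound 4 (0.38 log units; beyond the scatter) and a 6.7-fold lower number from compound 1 to compound 4 (0.83 log units; beyond the scatter), which makes it the most potent of these four. Nothing shown here explains why bromo and fluoro differ in this way.

From the compounds shown here alone, it remains open whether chloro, iodo or a methoxy group on the same carbon would match bromo. It is also unknown whether an amine or a carboxylic acid would be tolerated there.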